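Compound 4: hydrogen in place of sulfamoyl

The source may report more compounds than this note shows. Statements on the series, on what has been measured and on what is new or still open speak of the compounds shown alone.

Values so far in a functional assay on MV4-11 cells (Homo sapiens) for inhibition, read by resazurin assay, with a stated time of 72 h; a higher number here means a weaker inhibitor of growth, a lower number a stronger inhibitor of growth
compound 1 `NS(=O)(=O)c1cccc(Nc2ncc3c(n2)CCCC3)c1` gives 2550 nM
compound 2 `Cc1ccccc1Nc1ncc2c(n1)CCCC2` reports only a limit (> 10000 nM)
compound 3 `COc1cccc(Nc2ncc3c(n2)CCCC3)c1` gives 2280 nM

Compound 1 has a single numeric neighbour in this small set, and the step to it is a 1.1-fold lower number from compound 1 to compound 3 (0.05 log units; within the scatter). Among the measured compounds shown here, compound 2 reports only a limit (> 10000 nM) and gives no step to work with.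

Compound 4 `c1ccc(Nc2ncc3c(n2)CCCC3)cc1` differs from compound 1 in one place, with hydrogen in place of sulfamoyl on an aromatic carbon. For the measured compounds named here, the only measured step at that place is the exchange of sulfamoyl for methoxy. Compound 3 (2280 nM) shows that this exchange leaves the number within the scatter of compound 1. Going by the values given here, no measured step removes the group and leaves hydrogen, so this single comparison is weak support, and the range must stay wide. Among the compounds with values here, a number somewhat higher than that of compound 1 remains possible, though no step clearly beyond the scatter is expected. In this assay the expected step is a 1.4-fold higher number from compound 1 to compound 4 (0.14 log units; within the scatter). Compound 4 is estimated at 3500 nM (expected range 1500 nM to 9000 nM).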

Compound 4, concentration for 50% growth inhibition: 9830 nM
Estimate against measurement, compound 4: 2.8-fold (0.45 log units) below; measured number above the stated range.
By their numbers in this assay, from the lowest: compounds 3 and 1 (each within the scatter of the next); then compound 4. At a limit, above all of these: compound 2.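

In this assay, compounds 1 and 3 alone left it unclear whether a group on this aromatic carbon counts for anything, as sulfamoyl and methoxy were interchangeable within the scatter. Compound 4 settles that for these two groups: with hydrogen in their place there is a 3.9-fold higher number from compound 1 to compound 4 (0.59 log units; beyond the scatter), and likewise a 4.3-fold higher number from compound 3 to compound 4 (0.63 log units; beyond the scatter), so among these three compounds a substituent on this carbon goes with a lower number than hydrogen, even though sulfamoyl and methoxy share little beyond their place. Compound 2 reports only a limit: the limit of > 10000 nM in this assay, at which 1 of the 4 values shown sits. Hydrogen in place of methyl gives an at least 1.0-fold lower number from compound 2 to compound 4 (0.00 log units; that floor lies within the scatter), so compound 2, with methyl, does not share the pattern of compounds 1 and 3.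

The compounds shown do not tell whether the gain belongs to sulfamoyl and methoxy in particular or to almost any group on this carbon, and a plain amine, a carboxylic acid or a longer alkoxy chain there would help to separate the two. Nor do they show whether any group on this carbon can bring the number clearly below those of compounds 1 and 3, which so far stand level.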